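A Second Chloro Group on Compound 2

The source may hold more compounds than are shown below. What is called first, only, known or untested is meant among the compounds shown, and "the series" means these compounds.

Compound 1 `Cc1cc(NC(=O)Nc2cccnc2)c2ccccc2n1` and compound 2 `Cc1cc(NC(=O)Nc2ccc(Cl)cc2)c2ccccc2n1` share a core and were both tested in an ADME assay on Raji cells (Homo sapiens) for cytotoxicity, with a stated time of 72 h; on this read-out lower numbers stand for an effect already at smaller amounts and higher numbers for an effect only at larger amounts of compound. Compound 1 gives > 25000 nM, which is a limit of the assay and not a number. Compound 2 gives > 25000 nM, which is also a limit. Compound 2 therefore has no exact position on this scale, and the evidence shows (the limit of > 25000 nM in this assay, at which 2 of the 2 values shown sit).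

Compound 3 `Cc1cc(NC(=O)Nc2ccc(Cl)cc2Cl)c2ccccc2n1` differs from compound 2 by one change: chloro in place of hydrogen on an aromatic carbon. Among the compounds with values here, the only measured step that bears on it is a step that the two limits leave unreadable from compound 1 to compound 2. That step has no readable size to carry over, so no step beyond the scatter is expected in this assay, and another limit is the likeliest result. The estimated step is a number no higher from compound 2 to compound 3 (the limit leaves the size open). For compound 3 the expected value is 25000 nM, with an estimated range from 10000 nM to 50000 nM.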

Compound 3, half-maximal effective concentration: > 25000 nM
Compound 3 ended at the assay's limit (the forecaster's own chance of this, stated with the estimate: 75%); the middle value lies on the limit itself.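

No step can be read between compound 2 and compound 3, because both results are limits of the assay and not numbers: the limit of > 25000 nM in this assay, at which 3 of the 3 values shown sit.

The compounds shown leave open whether the added chloro group changes anything in this assay, and at what concentration compound 1, compound 2 or compound 3 would show an effect.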